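The source may report more compounds than this note shows. Statements on the series, on what has been measured and on what is new or still open speak of the compounds shown alone.

Measured in a functional assay on HL-60 cells (Homo sapiens) for inhibition, read by MTT assay, with a stated time of 72 h; on this read-out higher numbers stand for weaker inhibition and lower numbers for stronger inhibition:
compound 1 `COc1cc(OC)cc(N2CCN(C(=O)c3oc(C)nc3-c3ccccc3F)CC2)c1`: 10.3 nM
compound 2 `Cc1nc(-c2ccccc2)c(C(=O)N2CCN(c3cccc(C(F)(F)F)c3)CC2)o1`: 153 nM

Compound 2 holds the higher of the two numbers, and its gap to compound 1 lies beyond the scatter. Compound 3 `COc1cc(OC)cc(N2CCN(C(=O)c3oc(C)nc3-c3ccccc3)CC2)c1` is not yet measured. It follows from compound 2 by 3,5-dimethoxyphenyl in place of 3-(trifluoromethyl)phenyl on an amine nitrogen in a ring. Among the measured compounds shown here, no measured pair isolates this change. The 3,5-dimethoxyphenyl group also stands in compound 1 at 10.3 nM, so a fall in this assay beyond the scatter, towards stronger inhibition, is expected. The estimated step is a 7.0-fold lower number from compound 2 to compound 3 (0.84 log units; beyond the scatter). The estimate for compound 3 is 22 nM, with an expected range of 7 nM to 70 nM.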

Compound 3, half-maximal inhibitory concentration: 19.2 nM
Estimate against measurement, compound 3: 1.1-fold (0.06 log units) above, within the range that was stated.
By their numbers in this assay, from the lowest: compounds 1 and 3 (each within the scatter of the next); then compound 2.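

In this assay, 3,5-dimethoxyphenyl in place of 3-(trifluoromethyl)phenyl on the ring amine nitrogen can now be read as a single change, and it gives an 8.0-fold lower number from compound 2 to compound 3 (0.90 log units; beyond the scatter). Hydrogen in place of fluoro on an aromatic carbon gives a 1.9-fold higher number from compound 1 to compound 3 (0.27 log units; within the scatter), so this one pair shows no effect of that exchange beyond the scatter. Nothing available explains either step. Open, going by these compounds, is how a phenyl ring carrying a single methoxy group, or a benzyl group on that nitrogen, would read in this assay. On these data alone, the reading of either step in other cell lines also remains open.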